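The compounds below may be only part of what the source reports. "The series", "measured", "known", "first", "only" and "open" are said of these compounds alone.

Working notes on the series. Compound 1 `NS(=O)(=O)c1ccc(SCCO)c(F)c1` and compound 2 `NS(=O)(=O)c1ccc(S(=O)(=O)CCCO)c(F)c1` differ in more than one place; how the two cores differ is not broken down here. In a physicochemical assay for acid dissociation, compound 1 gives 9.76, and compound 2 gives 9.02, the lowest of the three measured numbers, with its steps to the other two beyond the scatter. Compound 3 `NS(=O)(=O)c1ccc(SCCO)c([N+](=O)[O-])c1` carries nitro in place of fluoro on an aromatic carbon. In this assay compound 3 gives 9.42, which makes the measured step of a number 0.34 log units lower from compound 1 to compound 3 (beyond the scatter).

Compound 4 `NS(=O)(=O)c1ccc(S(=O)(=O)CCCO)c([N+](=O)[O-])c1` is not yet measured and carries nitro in place of fluoro on an aromatic carbon. This is the same kind of change as that from compound 1 to compound 3, but not the same: the place is ortho to a (2-hydroxyethyl)sulfanyl group (4 heavy atoms) in the one case and ortho to a group of 7 heavy atoms in the other, while being meta to a sulfamoyl group (4 heavy atoms) in both. The change has been measured once only, so any expectation for compound 4 rests on a single instance and on the standing of compound 2.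

For the measured compounds named here, the expected step is a number 0.32 log units lower from compound 2 to compound 4 (beyond the scatter), set beside the measured step, because a number 0.34 log units lower from compound 1 to compound 3 (beyond the scatter) is the one measured instance of this kind of change. For compound 4 in this assay the estimate is 8.7, with a range from 8.3 to 9.1. This rests on compound 2 at 9.02 carried down by a step of roughly the measured size.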

Compound 4, acid dissociation constant: 8
Beside the measured number, compound 4's estimate is 0.70 log units above it; measured number below the stated range.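

In this assay the same change, nitro in place of fluoro on an aromatic carbon, gives a number 1.02 log units lower from compound 2 to compound 4 (beyond the scatter) and stands against a number 0.34 log units lower from compound 1 to compound 3 (beyond the scatter) in the other core, so the direction of the step carries across these two cores while its size does not. The step is printed as large in the one core and modest in the other, which shows that a size read from a single pair could not be carried over to the second core, but with one pair per core it gives no rule for any further core. Nothing at hand bears on the difference in size between the two steps.

Compounds 1 and 2 differ in more than one place, so the compounds shown leave open which part of that difference goes with the larger step, the state of the sulfur or the length of the hydroxyl-bearing chain. Also open, as far as these compounds go, is whether a nitrile or a trifluoromethyl on the same aromatic carbon would follow the modest step or the large one, and how either core would respond with a longer chain or an amine at the end of that chain.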